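Working notes: 4-(trifluoromethyl)phenyl in place of 3,4-difluorophenyl

This account rests on a few compounds, and the source may have more. Where it says the series, first, only, none or still open, it means among the compounds named here.

Measured in an ADME assay on MT2 cells (Homo sapiens) for cytotoxicity, read by XTT assay, with a stated time of 4 days; a lower number here means that less compound is tolerated, a higher number that more compound is tolerated:
- compound 1 `Cc1nc(C(NC(=O)C(=O)Nc2ccc(F)c(Cl)c2)C2CCCCN2)sc1CO`: > 77800 nM (a limit)
- compound 2 `Cc1nc(C(NC(=O)C(=O)Nc2ccc(Cl)c(F)c2)C2CCCCN2)sc1CO`: 77800 nM
- compound 3 `Cc1nc(C(NC(=O)C(=O)Nc2ccc(F)c(F)c2)C2CCCCN2)sc1CO`: > 87000 nM (a limit)

Compound 3 has no number in this assay, only the limit > 87000 nM.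

The next change gives compound 4 `Cc1nc(C(NC(=O)C(=O)Nc2ccc(C(F)(F)F)cc2)C2CCCCN2)sc1CO`, with 4-(trifluoromethyl)phenyl in place of 3,4-difluorophenyl on an amide-type nitrogen.

Within the data shown here, three measured steps bear on it, all among halogen-substituted phenyl groups on that same nitrogen. The first is a number no higher from compound 1 to compound 2 (the limit leaves the size open). The second is a step that the two limits leave unreadable from compound 1 to compound 3. The third, and the only one with a readable floor, is an at least 1.1-fold higher number from compound 2 to compound 3 (0.04 log units; that floor lies within the scatter). None of them gives a size beyond the scatter, and none involves a trifluoromethyl group, so the basis is thin.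

On the strength of an at least 1.1-fold higher number from compound 2 to compound 3 (0.04 log units; that floor lies within the scatter), no step beyond the scatter is expected in this assay, and a reading reported only as a limit is quite possible. The expected step is an at least 1.1-fold lower number from compound 3 to compound 4 (0.06 log units; that floor lies within the scatter). For compound 4 the estimated value is 75000 nM, with an expected range of 35000 nM to 120000 nM.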

Compound 4, half-maximal cytotoxic concentration: > 75500 nM
Compound 4 was reported as a limit (the forecaster's own chance of this, stated with the estimate: 55%); middle value at least 1.0-fold (0.00 log units) from the limit.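

In this assay compound 4 gives > 75500 nM, which is a limit. Among these compounds, no step from compound 1, compound 2 or compound 3 to compound 4 can be read. The compounds shown leave open where the half-maximal cytotoxic concentration of compound 4 lies, and whether 4-(trifluoromethyl)phenyl in place of 3,4-difluorophenyl shifts it at all.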